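The source may report more compounds than this note shows. Statements on the series, on what has been measured and on what is new or still open speak of the compounds shown alone.

In a functional assay on CNE-2 cells (Homo sapiens) for antiproliferative activity, read by sulforhodamine B assay, with a stated time of 48 h (on this read-out lower numbers stand for stronger inhibition and higher numbers for weaker inhibition), three compounds have been measured. Compound 1 (`COc1ccc(OC)c(/C=C/C(=O)/C=C(O)/C=C/c2cc(OC)ccc2OC)c1`) stands at 14700 nM and compound 2 (`COc1ccc(/C=C/C(=O)C(=Cc2ccc(O)c(OC)c2)C(=O)/C=C/c2ccc(OC)cc2OC)c(OC)c1`) at 970 nM while compound 3 (`COc1cc(OC)c(/C=C/C(=O)C(=Cc2ccc(O)c(OC)c2)C(=O)/C=C/c2c(OC)cc(OC)cc2OC)c(OC)c1`) stands at 1350 nM on the same read-out. Compound 3 thus lies within the usual scatter of compound 2, and both numbers sit well under that of compound 1.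

Compound 4 (`COc1cc(OC)c(/C=C/C(=O)C(=Cc2cc(Br)c(O)c(OC)c2)C(=O)/C=C/c2c(OC)cc(OC)cc2OC)c(OC)c1`) departs from compound 3 by a single change (bromo in place of hydrogen on an aromatic carbon), with bromo in place of hydrogen on an aromatic carbon, ortho to a hydroxy group. The group 4-hydroxy-3-methoxyphenyl thereby becomes 3-bromo-4-hydroxy-5-methoxyphenyl. Among the measured compounds shown here, no measured pair shows this change, so the data give no direct guide to its size. In this assay no step beyond the scatter is expected, with only a slight lean toward a lower number. The estimated move is a 1.4-fold lower number from compound 3 to compound 4 (0.13 log units; within the scatter) and it remains an expectation. Starting from compound 3 at 1350 nM as the anchor, compound 4 is expected at 1000 nM with an estimated range of 400 nM to 2700 nM on this read-out.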

Compound 4, half-maximal inhibitory concentration: 1320 nM
Estimate against measurement, compound 4: 1.3-fold (0.12 log units) below; measured number inside the range.
By their numbers in this assay, from the lowest: compounds 2, 4 and 3 (each within the scatter of the next); then compound 1.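

In this assay, bromo in place of hydrogen on this aromatic carbon, ortho to a hydroxy group, gives a 1.0-fold lower number from compound 3 to compound 4 (0.01 log units; within the scatter), a step within the scatter. Among the compounds shown here, this is the first step between compounds that differ in one place, and it shows that 4-hydroxy-3-methoxyphenyl can become 3-bromo-4-hydroxy-5-methoxyphenyl with no shift beyond the scatter on this read-out. Nothing at hand accounts for this result.

Going by these compounds, whether chloro, an amine or a carboxylic acid on the same carbon would also leave the number within the scatter remains open. On these data alone, it is also open whether the same bromo would give a similar step on compound 2, or with a methoxy group in place of the neighbouring hydroxy group.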